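The source may report more compounds than this note shows. Statements on the series, on what has been measured and on what is new or still open speak of the compounds shown alone.

Series notes. Of the compounds shown here, three carry a value so far. Compound 1 `COC(=O)C1=C(C)NC(C)=C(C(=O)OC)C1c1ccccc1` gives 28.2 nM in a functional assay (muscle tissue) with Cavia porcellus as the target; on this read-out higher numbers stand for an effect only at larger amounts of compound and lower numbers for an effect already at smaller amounts. Compound 2 `COC(=O)C1=C(C)N=C(C)/C(=C(\O)OC)C1c1cccc(N(C)C)c1` gives 891 nM in this assay. Compound 3 `COC(=O)C1=C(C)N=C(C)/C(=C(\O)OC)C1c1cc([N+](=O)[O-])ccc1Cl` gives 30.2 nM in this assay. On these numbers compound 2 stands highest of the three; its nearest neighbour is compound 3, and the gap to compound 1 is of a similar size, both beyond the scatter. Compound 1 and compound 3 lie within the scatter of each other, so no order is read between them.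

The next compound, compound 4 `COC(=O)C1=C(C)N=C(C)/C(=C(\O)OC)C1c1cccc(C)c1`, has not been measured. It differs from compound 2 in one place: methyl in place of dimethylamino on an aromatic carbon. Within the data shown here, no measured pair shows this same change, so no step for it is known. The change sits on an aromatic carbon of a six-membered aromatic ring of carbon only, and methyl is the smaller group of the two.

Given that compound 2 is the outlier of the set, the expectation for compound 4 is a number closer to the other two, that is, a step downward from compound 2 beyond the scatter, estimated as a 7.4-fold lower number from compound 2 to compound 4 (0.87 log units; beyond the scatter). Compound 4 is expected at 120 nM, within a range of 30 nM to 450 nM, since the remaining compounds sit near compound 1 at 28.2 nM.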

Compound 4, half-maximal effective concentration: 110 nM
Estimate against measurement, compound 4: 1.1-fold (0.04 log units) above; low and high end bracket the measured number.
By their numbers in this assay, from the lowest: compounds 1 and 3 (each within the scatter of the next); then compound 4; then compound 2.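

Working notes on this position: in this assay, methyl in place of dimethylamino on the aromatic carbon gives an 8.1-fold lower number from compound 2 to compound 4 (0.91 log units; beyond the scatter) and is the first measured step in the series, so the number at this position moves with the group it carries. In this one pair the smaller group, with no nitrogen and no hydrogen-bond acceptor, carries the lower number, but a single pair sets no trend. Nothing measured here bears on why the number moves with this change.

This step changes size and nitrogen content together, and the two cannot be separated on these compounds. Open, from the compounds shown here alone, is how a methoxy group, a primary amine or a longer alkyl chain on the same aromatic carbon would read, and whether any of them would fall nearer to methyl or to dimethylamino.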